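The source may hold more compounds than are shown below. What is called first, only, known or untested is meant among the compounds shown, and "the series" means these compounds.

In an assay on isolated protein (Cricetulus griseus) for binding affinity to Alpha-1B adrenergic receptor (Mesocricetus auratus), read by radioligand binding (on this read-out higher numbers stand for weaker inhibition and lower numbers for stronger inhibition), compound 2 `CS(=O)(=O)Nc1c(O)ccc2c1CCCC2c1c[nH]cn1` gives 2510 nM, and that is the only measured number shown for this set. Compound 1 `CC(C)S(=O)(=O)Nc1cccc2c1CCCC2c1c[nH]cn1` is recorded only as a limit of the assay in this assay, at < 10000 nM, so it gives no number to compare with. Compound 3 `COc1ccc2c(c1NS(C)(=O)=O)CCCC2c1c[nH]cn1` has not yet been measured. It differs from compound 2 in one place: methyl in place of hydrogen on an oxygen on an aromatic ring. Going by the values given here, no step between two measured compounds is available to show how such a change has behaved here, so the expectation for compound 3 rests on compound 2 alone and on the smallness of the change. Compound 3 is expected to land at 3000 nM, within a range from 800 nM to 12000 nM. The estimated step from compound 2 to compound 3 of a 1.2-fold higher number from compound 2 to compound 3 (0.08 log units; within the scatter) is expected to stay within the usual scatter of repeated measurements, in no settled direction.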

Compound 3, inhibition constant: 1700 nM
For compound 3 the middle estimate is 1.8-fold (0.25 log units) above the measured one, and the stated range covers the measured number.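

Going from hydroxy to methoxy on the aromatic ring gives the first step that can be read in this assay, a 1.5-fold lower number from compound 2 to compound 3 (0.17 log units; within the scatter), so the two compounds cannot be told apart in this measurement. The hydrogen on that oxygen can therefore give way to methyl without a difference that stands clear of the usual scatter. This rests on a single pair of compounds, so it describes this one replacement and sets no trend for the position.

On these data alone, whether a longer chain on that oxygen, or an amine in place of the hydroxy group, would give a clearly different number stays open. Compound 1 is recorded only as a limit and not as a number, so it adds no further step to read: the limit of < 10000 nM in this assay, at which 1 of the 3 values shown sits.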